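Removing a Cyclohexyl Group from a Keto-Acid Inhibitor

The compounds below may be only part of what the source reports. "The series", "measured", "known", "first", "only" and "open" are said of these compounds alone.

Measured compounds:
Compound 1, `Cc1cc(C2CCCCC2)c(C)cc1C(=O)/C=C/C(=O)O`: 6640 nM
Compound 2, `CC(C)(C)c1ccc(C(=O)/C=C/C(=O)O)cc1`: 8740 nM

In a functional assay on LS174T cells (Homo sapiens) for inhibition, read by MTT assay, with a stated time of 72 h (on this read-out lower numbers stand for stronger inhibition and higher numbers for weaker inhibition), compound 1 gives 6640 nM, and compound 2 gives 8740 nM. Compound 1 stands with compound 2 as two numbers that lie within the usual scatter of each other, so the two cannot be told apart on this read-out.

Compound 3, `Cc1ccc(C)c(C(=O)/C=C/C(=O)O)c1`, has not yet been measured in this assay. It differs from compound 1 in one place: hydrogen in place of cyclohexyl on an aromatic carbon. For the measured compounds named here, nothing measured so far shows what this change does. With a large cyclohexyl replaced by hydrogen, a modest weakening of inhibition is expected, so the step from compound 1 to compound 3 is estimated as a 2.3-fold higher number from compound 1 to compound 3 (0.35 log units; beyond the scatter), beyond the scatter but not large. Compound 3 is therefore expected to give about 15000 nM in this assay, within a range of 5000 nM to 45000 nM.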

Compound 3, half-maximal inhibitory concentration: 22000 nM
For compound 3 the middle estimate is 1.5-fold (0.17 log units) below the measured one; low and high end bracket the measured number.
By their numbers in this assay, from the lowest: compounds 1 and 2 (each within the scatter of the next); then compound 3.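

In this assay, replacing cyclohexyl with hydrogen on the aromatic carbon para to the (2-carboxyethenyl)carbonyl group gives a 3.3-fold higher number from compound 1 to compound 3 (0.52 log units; beyond the scatter) and so shows that the group on this carbon affects inhibition. The change does not abolish inhibition, since compound 3 still gives a measurable 22000 nM with only hydrogen there. The data offer no explanation for the rise in the number.

On these data alone, it remains open whether an ethyl chain, a phenyl ring or an amine on this same carbon would bring the number back toward that of compound 1. The part played by the two methyl groups also remains open, as no pair of compounds shown differs in those groups alone.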